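A Tertiary Amine Replaces the Imidazole on the Tail

The compounds below may be only part of what the source reports. "The series", "measured", "known", "first", "only" and "open" are said of these compounds alone.

Compound 3 `CCCCCCCCCCCC(=O)OC[C@H](CSC[C@@H](N)C(=O)NCCCn1ccnc1)OC(=O)CCCCCCCCCCC` gives 410 nM in an assay on HEK293 cells for agonist activity at Toll-like receptor 2 (Homo sapiens) (a lower number here means that less compound is needed, a higher number that more compound is needed for the effect), the lowest of the three numbers measured. Compound 1 `CCCCCCCCCCCC(=O)OC[C@H](CSC[C@@H](N)C(=O)NCCCS(=O)(=O)O)OC(=O)CCCCCCCCCCC` gives 5560 nM, and compound 2 `CCCCCCCCCCCC(=O)OC[C@H](CSC[C@@H](N)C(=O)NCCCCCCCCCC(=O)O)OC(=O)CCCCCCCCCCC` gives 4400 nM; the step of a 1.3-fold lower number from compound 1 to compound 2 (0.10 log units; within the scatter) is within the scatter, whereas a 14-fold lower number from compound 1 to compound 3 (1.13 log units; beyond the scatter) and an 11-fold lower number from compound 2 to compound 3 (1.03 log units; beyond the scatter) are both large. Compound 4 `CCCCCCCCCCCC(=O)OC[C@H](CSC[C@@H](N)C(=O)NC(C)CCN(CC)CC)OC(=O)CCCCCCCCCCC` differs from compound 3 by 3-(diethylamino)-1-methylpropyl in place of 3-(1H-imidazol-1-yl)propyl on an amide-type nitrogen. Within the data shown here, the two large steps bear on this change only in that the imidazolyl group entering went with the lower numbers; no measured step shows a diethylamino group. Compound 4 is therefore expected to give a higher number than compound 3, a 3.7-fold higher number from compound 3 to compound 4 (0.56 log units; beyond the scatter). Compound 4 is estimated at 1500 nM, with a range from 300 nM to 6000 nM.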

Compound 4, half-maximal effective concentration: 257 nM
The estimate for compound 4 lay 5.8-fold (0.77 log units) above the measured number; the whole stated range lies above it.
By their numbers in this assay, from the lowest: compounds 4 and 3 (each within the scatter of the next); then compounds 2 and 1 (each within the scatter of the next).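

On the amide-type nitrogen, the open-chain 3-(diethylamino)-1-methylpropyl group, which has no ring, does as well as the 3-(1H-imidazol-1-yl)propyl group in this assay (a 1.6-fold lower number from compound 3 to compound 4 (0.20 log units; within the scatter)). Among these compounds, then, the five-membered aromatic ring is not needed at this position. The new group also keeps the large distance from the 9-carboxynonyl tail (a 17-fold lower number from compound 2 to compound 4 (1.23 log units; beyond the scatter)) and the 3-sulfopropyl tail (a 22-fold lower number from compound 1 to compound 4 (1.34 log units; beyond the scatter)).

The 1-methyl branch and the diethylamino group enter together, and a 3-(diethylamino)propyl tail without the methyl would separate them. No evidence at hand bears on this result.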